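Heteroaryl amide replacements and efficacy at the fatty acid receptor

The compounds below may be only part of what the source reports. "The series", "measured", "known", "first", "only" and "open" are said of these compounds alone.

Measured so far:
Compound 1, `CC(C)[C@H](C(=O)Nc1ccc(F)cn1)c1ccc(Cl)cc1`: in a functional assay on CHO cells for agonist activity at Free fatty acid receptor 2 (Homo sapiens), read by cAMP accumulation (a lower number here means a smaller maximal response, a higher number a larger maximal response), compound 1 gives 93%.
Compound 2, `CC(C)[C@H](C(=O)Nc1ncns1)c1ccc(Cl)cc1`: in this assay compound 2 gives 99%.
Compound 3, `Cc1csc(NC(=O)[C@H](c2ccc(Cl)cc2)C(C)C)n1`: in this assay compound 3 gives 87%.

Compound 3 sits at the low end of these three numbers: its distance to compound 1 is within the usual scatter, and only its distance to compound 2 lies beyond it. The three steps that exchange the heteroaryl group on the amide-type nitrogen are a number 6 percentage points higher from compound 1 to compound 2 (within the scatter), a number 6 percentage points lower from compound 1 to compound 3 (within the scatter) and a number 12 percentage points lower from compound 2 to compound 3 (beyond the scatter). All three are small, and the largest is only modest.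

Compound 4 is `CC(C)[C@H](C(=O)Nc1ncc(C#N)s1)c1ccc(Cl)cc1`. Relative to compound 3 the change is 5-cyano-1,3-thiazol-2-yl in place of 4-methyl-1,3-thiazol-2-yl on an amide-type nitrogen. The ring type stays the same and only the substituent on it is exchanged, so the bearing steps are those three heteroaryl exchanges, none of which moved the maximal response far. The step of a number 5 percentage points higher from compound 3 to compound 4 (within the scatter) is therefore expected to remain within the scatter, with no clear direction. Compound 4 is estimated at 92%, in a range from 80% to 102%.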

Compound 4, largest response reached (reported as efficacy), in percent of the reference or control that the assay uses: 105%
The estimate for compound 4 lay 13 percentage points below the measured number; measured number outside the range, above it.
By their numbers in this assay, from the lowest: compounds 3, 1, 2 and 4 (each within the scatter of the next, the first and the last beyond it).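

Within the one ring type, the substituent exchange alone gives a step beyond the scatter in this assay: a number 18 percentage points higher from compound 3 to compound 4 (beyond the scatter), so this group on the amide-type nitrogen is not limited to small shifts in maximal response. The comparison with the other rings is split: a number 12 percentage points higher from compound 1 to compound 4 (beyond the scatter), which also lies beyond the scatter, whereas a number 6 percentage points higher from compound 2 to compound 4 (within the scatter), which leaves compound 2 and compound 4 without an order. No measurement here accounts for the step from the methyl to the cyano compound.

Compound 3 and compound 4 differ in both the group and its place on the ring, so the effect of each remains unseparated; 5-methyl-1,3-thiazol-2-yl and 4-cyano-1,3-thiazol-2-yl would divide them. Also open, from the compounds shown here alone, is how 5-amino-1,3-thiazol-2-yl or a carboxylic acid on the same ring would behave.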